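Chloro for carbamoyl on a urea-linked quinaldine scaffold

The source may report more compounds than this note shows. Statements on the series, on what has been measured and on what is new or still open speak of the compounds shown alone.

The two measured compounds share a urea-linked core and were tested in an ADME assay on HEK293 cells (Homo sapiens) for cytotoxicity, with a stated time of 72 h; on this read-out lower numbers stand for an effect already at smaller amounts and higher numbers for an effect only at larger amounts of compound. Compound 1, `Cc1cc(NC(=O)Nc2ccccc2OC(F)(F)F)c2ccccc2n1`, returned only a limit of the assay, > 25000 nM, rather than a number. Compound 2, `Cc1cc(NC(=O)Nc2cccc(C(N)=O)c2)c2ccccc2n1`, likewise reached only the limit of the assay in this assay, > 25000 nM. Compound 2 therefore stands at the ceiling of what was measured, together with compound 1, as the record shows (the limit of > 25000 nM in this assay, at which 2 of the 2 values shown sit). Going by the values given here, no step between measured compounds is given, so nothing about the size of an effect can be read from the pair.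

Compound 3, `Cc1cc(NC(=O)Nc2cccc(Cl)c2)c2ccccc2n1`, is the unmeasured analogue of compound 2; it differs by chloro in place of carbamoyl on an aromatic carbon. For this change in this assay no step beyond the usual scatter is expected in either direction, since compound 2 itself gave no number but a limit. The value of compound 3 in this assay is expected to be around 30000 nM, within a range from 12000 nM to 80000 nM. The estimated step is a step that the limit leaves unreadable from compound 2 to compound 3, with a high chance that this assay again reports only a limit.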

Compound 3, half-maximal effective concentration: 21000 nM
For compound 3 the middle estimate is 1.4-fold (0.15 log units) above the measured one, within the range that was stated.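

In this assay, compound 3 is the only one of the compounds shown to return a number rather than a limit, 21000 nM. Chloro in place of carbamoyl on this aromatic carbon, meta to a large group, comes with an at least 1.1-fold lower number from compound 2 to compound 3 (0.07 log units; that floor lies within the scatter), and this floor is all that can be read, so the true step may be larger and its size remains unknown. The other two compounds remain at the ceiling of the read-out, so the change gives the series its one measured number, while the comparison itself stays bounded on one side only: the limit of > 25000 nM in this assay, at which 2 of the 3 values shown sit.

The compounds shown leave open whether this number belongs to chloro in particular or whether another group on the same carbon, such as methyl, an amine or a carboxylic acid, would also give a number rather than a limit. Going by these compounds, compound 1 differs from compound 3 in more than one place, so it cannot show what the trifluoromethoxy group contributes, and whether chloro would give a number on the ring of compound 1 also remains open.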